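Adding a Bromo Group to a Compound at the Assay Limit

A few compounds are considered here, and "the series" means these few. Any claim that something is new, unique, unknown or untested is made for them only; others in the source may bear on it.

Compound 1 `S=C(N/N=C/c1cccs1)Nc1ccccc1` was examined in a functional assay on HT-29 cells (Homo sapiens) for inhibition, read by sulforhodamine B assay, with a stated time of 48 h; a lower number here means a stronger inhibitor of growth, a higher number a weaker inhibitor of growth. In this assay compound 1 gives > 100000 nM, which is a limit of the assay and not a number. Compound 2 `C=CCNC(=S)N/N=C/c1cccs1` gives > 100000 nM in the same test, and this too is a limit. The record so far is therefore (the limit of > 100000 nM in this assay, at which 2 of the 2 values shown sit). Within the data shown here, no two measured compounds differ in one place, so no measured step is available as a guide.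

Compound 3 `S=C(N/N=C/c1cccs1)Nc1ccc(Br)cc1` departs from compound 1 by a single change: bromo in place of hydrogen on an aromatic carbon. This places bromo in place of hydrogen on an aromatic carbon, para to a large group. A modest step towards stronger inhibition of growth in this assay is expected, although compound 3 may well return only a limit again. Such an expectation is loose, since no measured number exists from which to start. The estimated change is an at least 1.6-fold lower number from compound 1 to compound 3 (0.22 log units; that floor lies within the scatter). For compound 3 the expected value is 60000 nM, with an estimated range from 15000 nM to 100000 nM.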

Compound 3, concentration for 50% growth inhibition: 17700 nM
The estimate for compound 3 lay 3.4-fold (0.53 log units) above the measured number; measured number inside the range.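

In this assay, bromo in place of hydrogen on an aromatic carbon, para to a large group, gives an at least 5.6-fold lower number from compound 1 to compound 3 (0.75 log units; beyond the scatter), and this step lies beyond the usual scatter. Compound 3 is the only one of the three compounds shown that returns a number and not a limit, so this position on the six-membered aromatic ring of compound 1 is one where a single added bromine atom is enough to bring growth inhibition into the measurable range of the test. The step remains a floor and its true size cannot be stated, because its starting point is a limit of the assay and not a number: the limit of > 100000 nM in this assay, at which 2 of the 3 values shown sit.

The compounds shown leave open whether this change is specific to bromo or would also appear with another group at the same place, such as chloro, methyl, methoxy or trifluoromethyl. They also leave open whether bromo would act in the same way elsewhere on that ring, and whether a larger group at this position, such as phenyl, would move the number further in either direction.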